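A few compounds are considered here, and "the series" means these few. Any claim that something is new, unique, unknown or untested is made for them only; others in the source may bear on it.

The measured compounds are these. Compound 1 `Cc1nc(S(C)(=O)=O)ccc1Oc1ncnc(OC2CCN(C(=O)OC(C)(C)C#N)CC2)c1F` gives 92.9 nM in a functional assay on isolated protein for inhibition of Glucose-dependent insulinotropic receptor (Homo sapiens), read by HTRF and cAMP accumulation; a lower number here means that less compound is needed, a higher number that more compound is needed for the effect. Compound 2 `Cc1nc(S(C)(=O)=O)ccc1Oc1ncnc(OC2CCN(C(=O)O[C@H](C)C(F)(F)F)CC2)c1F` gives 9.2 nM in this assay. Compound 3 `CCC1(OC(=O)N2CCC(Oc3ncnc(Oc4ccc(S(C)(=O)=O)nc4C)c3F)CC2)CC1` gives 22 nM in this assay.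

Among these three numbers compound 3 stands second highest: its nearest neighbour is compound 2, with a 2.4-fold higher number from compound 2 to compound 3 (0.38 log units; beyond the scatter), and its furthest is compound 1, with a 4.2-fold lower number from compound 1 to compound 3 (0.63 log units; beyond the scatter). The remaining step, a 10-fold lower number from compound 1 to compound 2 (1.00 log units; beyond the scatter), shows that the three variations of the group on the oxygen of the carbamate all stay within a modest span.

Compound 4 `CCC(F)(F)C(=O)N1CCC(Oc2ncnc(Oc3ccc(S(C)(=O)=O)nc3C)c2F)CC1` is not yet measured. It differs from compound 3 in this way: a group of 5 heavy atoms (3 carbon, 2 fluorine; no ring) in place of a group of 6 heavy atoms (5 carbon, 1 oxygen; one three-membered non-aromatic ring of carbon only), on a carbonyl carbon. Within the data shown here, none of the measured steps makes this same change; all three alter only the group on the carbamate oxygen, whereas here the oxygen itself leaves along with its ring. They bear on the question only in showing that this end of the molecule tolerates several modest changes without a large shift in this assay. On that basis compound 4 is expected to land near compound 3, with a 1.4-fold higher number from compound 3 to compound 4 (0.13 log units; within the scatter), in no clear direction. The estimate for compound 4 in this assay is 30 nM, between 8 nM and 120 nM.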

Compound 4, half-maximal effective concentration: 17.4 nM
Beside the measured number, compound 4's estimate is 1.7-fold (0.24 log units) above it; the measured number falls inside the stated range.
By their numbers in this assay, from the lowest: compounds 2, 4 and 3 (each within the scatter of the next, the first and the last beyond it); then compound 1.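

The result shows that the carbamate oxygen can go from this position without a shift that this assay can resolve: with 1,1-difluoropropyl on the carbonyl carbon, so that compound 4 is an amide rather than a carbamate, there is a 1.3-fold lower number from compound 3 to compound 4 (0.10 log units; within the scatter) and a 1.9-fold higher number from compound 2 to compound 4 (0.28 log units; within the scatter). The earlier compounds shown here varied only the group on that oxygen, so they could not show that a change reaching the atom bound to the carbonyl carbon is also tolerated here. The difference from the nitrile-bearing carbamate stays clear, with a 5.3-fold lower number from compound 1 to compound 4 (0.73 log units; beyond the scatter), and nothing at hand explains why this exchange is tolerated.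

The compounds shown leave open what the two fluorines of 1,1-difluoropropyl contribute, since the plain propyl amide does not appear among them, and whether the carbonyl carbon would accept a nitrogen-linked group, such as a dimethylamine forming a urea, as readily as it accepts this carbon-linked one. They also leave open whether a longer chain, such as 1,1-difluorobutyl, would stay within the same narrow span.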